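The source may hold more compounds than are shown below. What is called first, only, known or untested is meant among the compounds shown, and "the series" means these compounds.

Working notes on the series, read in a physicochemical assay, read by spectrophotometry, with a stated time of 6 min; a higher number here means a weaker inhibitor, a lower number a stronger inhibitor. Compound 1 (`O=C(CCc1nc2ccccc2c(=O)[nH]1)N/N=C/c1ccc(O)c(O)c1`) gives 40000000 nM. Compound 3 (`COc1cc(/C=N/NC(=O)CCCc2nc3ccccc3c(=O)[nH]2)cc(O)c1O`) gives 50000000 nM, within the scatter of compound 1. Compound 2 (`COc1cc(/C=N/NC(=O)CCCc2nc3ccccc3c(=O)[nH]2)cc(OC)c1O`) gives 135000000 nM, a higher number than compound 1 and beyond the scatter.

Compound 4 (`COc1ccc(/C=N/NC(=O)CCc2nc3ccccc3c(=O)[nH]2)cc1`) is not yet measured. Its change from compound 1 is 4-methoxyphenyl in place of 3,4-dihydroxyphenyl on a carbon with a double bond to nitrogen.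

Within the data shown here, one measured step bears on this: a 2.7-fold lower number from compound 2 to compound 3 (0.43 log units; beyond the scatter), with hydrogen in place of methyl on an oxygen on an aromatic ring. The change to compound 4 runs the opposite way, so a modest rise in this assay is expected, resting on this single pair. The expected step is a 3.0-fold higher number from compound 1 to compound 4 (0.48 log units; beyond the scatter). For compound 4 the estimate is 120000000 nM, with an expected range of 50000000 nM to 300000000 nM.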

Compound 4, half-maximal inhibitory concentration: 75000000 nM
For compound 4 the middle estimate is 1.6-fold (0.20 log units) above the measured one; the measured number falls inside the stated range.
By their numbers in this assay, from the lowest: compounds 1, 3, 4 and 2 (each within the scatter of the next, the first and the last beyond it).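

Read in this assay the change to 4-methoxyphenyl in place of 3,4-dihydroxyphenyl on a carbon with a double bond to nitrogen gives a 1.9-fold higher number from compound 1 to compound 4 (0.27 log units; within the scatter) and so shows no shift beyond the scatter for a change of the whole group. This holds even though the entering group counts 0 hydrogen-bond donors against 2 for the leaving group, whereas the earlier step covered only hydrogen in place of methyl on an oxygen on an aromatic ring. Nothing on hand explains this result.

The compounds shown do not separate the contributions of the two hydroxy groups of compound 1. From the compounds shown here alone, how a phenyl ring carrying an amine or a carboxylic acid would read in this place also remains open.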